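The source may hold more compounds than are shown below. What is called first, only, known or untested is meant among the compounds shown, and "the series" means these compounds.

Compound 2 `O=[N+]([O-])c1ccc(NS(=O)(=O)c2ccc3nc(-c4ccccc4)c(-c4ccccc4)nc3c2)cc1` gives 87.6% in an ADME assay on the whole organism for pharmacokinetics, with Homo sapiens as the target (a higher number here means that a larger share of the oral dose reaches the circulation, a lower number that a smaller share of the oral dose reaches the circulation), the second highest of the three numbers measured. Compound 1 `O=[N+]([O-])c1cccc(NS(=O)(=O)c2ccc3nc(-c4ccccc4)c(-c4ccccc4)nc3c2)c1` gives 85.6% in this assay, and compound 3 `CC(=O)c1cccc(NS(=O)(=O)c2ccc3nc(-c4ccccc4)c(-c4ccccc4)nc3c2)c1` gives 96.9%. Neither step is large: a number 2 percentage points higher from compound 1 to compound 2 (within the scatter), and a number 9.3 percentage points higher from compound 2 to compound 3 (within the scatter). Compound 4 `O=S(=O)(Nc1ccc(Cl)cc1)c1ccc2nc(-c3ccccc3)c(-c3ccccc3)nc2c1` differs from compound 2 by chloro in place of nitro on an aromatic carbon. Going by the values given here, the one measured step that also exchanges the nitro for another group is a number 11.3 percentage points higher from compound 1 to compound 3 (beyond the scatter). Since that exchange gave a small rise and the other steps stayed within the scatter, a step that is small or within the scatter is expected here. Compound 4 is therefore estimated at 90%, with a range from 76% to 100%. This estimate means a number 2.4 percentage points higher from compound 2 to compound 4 (within the scatter).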

Compound 4, oral bioavailability: 100%
Compound 4: middle estimate off by 10 percentage points, on the low side; measured number inside the range.
By their numbers in this assay, from the lowest: compounds 1, 2, 3 and 4 (each within the scatter of the next, the first and the last beyond it).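

In this assay chloro in place of nitro gives a number 12.4 percentage points higher from compound 2 to compound 4 (beyond the scatter) and so shows that exchanging the group at this place can carry the number past the scatter, which moving the nitro group around the ring did not do. The result is also a number 14.4 percentage points higher from compound 1 to compound 4 (beyond the scatter) but only a number 3.1 percentage points higher from compound 3 to compound 4 (within the scatter) and so does not separate the chloro compound from the acetyl compound. Nothing measured on these compounds accounts for the rise.

On these data alone, whether an amine, a carboxylic acid or a methoxy group at this place would keep the number as high remains open. So does whether chloro would have the same effect on the 3-nitrophenyl compound.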